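The compounds below may be only part of what the source reports. "The series", "measured", "known", "first", "only" and "open" are said of these compounds alone.

Measured compounds:
Compound 1, `COC(=O)c1c[nH]c2cc(OCCOc3ccccc3)c(C)cc2c1=O` — in an ADME assay on J774 cells (Mus musculus) for cytotoxicity (on this read-out lower numbers stand for an effect already at smaller amounts and higher numbers for an effect only at larger amounts of compound), compound 1 gives > 20000 nM, which is a limit of the assay rather than a number.
Compound 2, `CCCCc1cc2c(=O)c(C(=O)OCC)c[nH]c2cc1OCCOc1ccccc1` — in this assay compound 2 gives > 20000 nM, also a limit.
Compound 3, `CCCc1cc2c(=O)c(C(=O)OC)c[nH]c2cc1OCCOc1ccccc1` — in this assay compound 3 gives > 20000 nM, again a limit.

Compound 2 thus stands where every value shown sits: the limit of > 20000 nM in this assay, at which 3 of the 3 values shown sit. Among the measured compounds shown here, the only step between measured compounds, a step that the two limits leave unreadable from compound 1 to compound 3, cannot be read because both ends are limits. Compound 4, `CCCCc1cc2c(=O)c(I)c[nH]c2cc1OCCOc1ccccc1`, differs from compound 2 by iodo in place of ethoxycarbonyl on an aromatic carbon. For the measured compounds named here, no measured step touches an iodo or an ethoxycarbonyl group, so nothing shows the size or direction of this change in this assay. Because all values sit at the limit of > 20000 nM in this assay, at which 3 of the 3 values shown sit, compound 4 is expected near 25000 nM, within 8000 nM to 60000 nM. The expected step is a step that the limit leaves unreadable from compound 2 to compound 4, most likely again only a limit.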

Compound 4, half-maximal effective concentration: > 10000 nM
Compound 4: only a limit was reported (the forecaster's own chance of this, stated with the estimate: 70%); the middle value lies beyond the limit too.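

Compound 2 and compound 4 both give only limits in this assay, and the step between them cannot be read. The compounds shown leave open what iodo in place of ethoxycarbonyl changes, and at what amount any of them takes effect.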